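This account rests on a few compounds, and the source may have more. Where it says the series, first, only, none or still open, it means among the compounds named here.

For the measured compounds named here, in a functional assay on the whole organism for inhibition, with Mus musculus as the target, read by paw edema, with a stated time of 180 min, at a dose of 200 mg/kg by the oral route (on this read-out higher numbers stand for a stronger effect at the one dose given and lower numbers for a weaker effect), compound 3 `Cc1ccc2oc(=O)n(CC(=O)NN)c2c1` gives 70.5%, the highest of the three numbers measured so far. Going by the values given here, compound 1 `CCCn1c(Cn2c(=O)oc3ccc(C)cc32)n[nH]c1=S` gives 44.3%, and compound 2 `CCn1c(Cn2c(=O)oc3ccc(C)cc32)n[nH]c1=S` gives 31.8%; the only step measured between neighbours, a number 12.5 percentage points lower from compound 1 to compound 2 (beyond the scatter), is a modest drop that sits beyond the usual scatter. Compound 4 `CCNC(=S)NNC(=O)Cn1c(=O)oc2ccc(C)cc21` differs from compound 3 by a group of 5 heavy atoms (3 carbon, 1 nitrogen, 1 sulfur; no ring) in place of a hydrogen atom, on an amine nitrogen. Among the compounds with values here, that measured step concerns a methyl on a saturated chain carbon, not an amine nitrogen, so it offers only a loose guide to a change of this kind, and no step at this position has been measured. A modest loss is expected, a number 15.5 percentage points lower from compound 3 to compound 4 (beyond the scatter). For compound 4 the expected value is 55%, with a range from 35% to 75%.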

Compound 4, a percentage reported as inhibition, in the whole organism at one dose (the size of the read-out at that dose, not a potency): 54.6%
Compound 4: the middle estimate sits 0.4 percentage points above what was measured; low and high end bracket the measured number.
By their numbers in this assay, from the lowest: compound 2; then compound 1; then compound 4; then compound 3.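

For the compounds shown here, this is the first change measured on this amine nitrogen: in this assay, placing the group of 5 heavy atoms there in place of a hydrogen atom gives a number 15.9 percentage points lower from compound 3 to compound 4 (beyond the scatter) and counts as a modest loss. The effect does not vanish, since compound 4 still gives 54.6% at the one dose used. Nothing available explains why the number falls. Going by these compounds, whether a smaller acetyl group on this nitrogen would cost less remains open. So does whether a phenyl ring at the far end of the added group would change the result.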